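Aryl amide variation on the sulfonamide series

This account rests on a few compounds, and the source may have more. Where it says the series, first, only, none or still open, it means among the compounds named here.

Compound 2 `COc1cc(OC)cc(C(=O)NCCNC(=O)[C@H](CC(=O)NC(C)(C)C)NS(=O)(=O)c2ccc(C)cc2)c1` stands at a limit: in an ADME assay on Karpas-1106P cells (Homo sapiens) for cytotoxicity (a lower number here means that less compound is needed, a higher number that more compound is needed for the effect), compound 2 gives > 11100 nM, a limit of the assay and not a number. Compound 1 `Cc1ccc(S(=O)(=O)N[C@@H](CC(=O)NC(C)(C)C)C(=O)NCCNC(=O)c2cc(C)ccc2F)cc1` gives in this assay the limit > 11100 nM. Compound 3 `Cc1ccc(S(=O)(=O)N[C@@H](CC(=O)NC(C)(C)C)C(=O)NCCNC(=O)c2ccc(F)c(F)c2)cc1` gives in this assay the limit > 11100 nM. The change 3-cyanophenyl in place of 3,5-dimethoxyphenyl on a carbonyl carbon yields compound 4 `Cc1ccc(S(=O)(=O)N[C@@H](CC(=O)NC(C)(C)C)C(=O)NCCNC(=O)c2cccc(C#N)c2)cc1`. The measured steps bearing on this change are a step that the two limits leave unreadable from compound 1 to compound 2 and a step that the two limits leave unreadable from compound 2 to compound 3, with a step that the two limits leave unreadable from compound 1 to compound 3 alongside; none is readable, since the limit of > 11100 nM in this assay, at which 3 of the 3 values shown sit, covers every value shown. No step beyond the scatter is therefore expected for compound 4 in this assay. Compound 4 is expected at 20000 nM, within 8000 nM to 60000 nM, most likely reported again as a limit. The step from compound 2 to compound 4 is thus estimated as a step that the limit leaves unreadable from compound 2 to compound 4.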

Compound 4, half-maximal effective concentration: > 11100 nM
Compound 4 was reported as a limit; the forecaster's own chance of this, stated with the estimate: 85%; the middle value lies beyond the limit too.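

No step from compound 4 to compound 1, compound 2 or compound 3 can be read in this assay: the limit of > 11100 nM in this assay, at which 4 of the 4 values shown sit.

The compounds shown leave open whether any aryl group on this carbonyl carbon gives a readable value.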